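Chalcone-pyrazole series: halogen swap on the aryl ketone

The source may report more compounds than this note shows. Statements on the series, on what has been measured and on what is new or still open speak of the compounds shown alone.

Measured so far in a functional assay on KM12 cells (Homo sapiens) for cytotoxicity, read by sulforhodamine B assay, with a stated time of 48 h, tested at 1 uM; on this read-out lower numbers stand for a stronger effect and higher numbers for a weaker effect at the one concentration tested:
compound 1 `COc1cc(-c2cc(/C=C/C(=O)c3ccc(Cl)c(Cl)c3)[nH]n2)cc(OC)c1OC` gives 85%
compound 2 `COc1ccc(-c2cc(/C=C/C(=O)c3ccc(N)cc3)[nH]n2)cc1` gives 77%
compound 3 `COc1cc(C(=O)/C=C/c2cc(-c3cc(OC)c(OC)c(OC)c3)n[nH]2)cc(OC)c1OC` gives 79%

Compound 1 has the highest of the three numbers in this assay, but its gap to compound 3 and its gap to compound 2 both lie within the usual scatter, so the three measured compounds cannot be told apart on these readings; none of them shows a strong effect at the single concentration tested.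

Compound 4 `COc1cc(-c2cc(/C=C/C(=O)c3ccc(F)c(F)c3)[nH]n2)cc(OC)c1OC` has not been measured. It differs from compound 1 in one place: 3,4-difluorophenyl in place of 3,4-dichlorophenyl on a carbonyl carbon. Going by the values given here, no pair of measured compounds differs in a single place, so there is no measured step to lean on. With compound 1 at 85% and every measured number sitting at the weak end, the step from one dihalophenyl to another is expected to be small, and a number 4 percentage points higher from compound 1 to compound 4 (within the scatter) is estimated to stay within the scatter, with no change in either direction that could be trusted. Compound 4 is therefore expected to give about 89% in this assay, between 76% and 100%.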

Compound 4, a percentage reported as activity, at one concentration (the size of the read-out at that concentration, not a potency): 95%
Estimate against measurement, compound 4: 6 percentage points below; the range from low to high includes it.
By their numbers in this assay, from the lowest: compounds 2, 3, 1 and 4 (each within the scatter of the next, the first and the last beyond it).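

The swap at this place gives the series its first single-change step: 3,4-difluorophenyl in place of 3,4-dichlorophenyl on a carbonyl carbon gives a number 10 percentage points higher from compound 1 to compound 4 (within the scatter) in this assay on an otherwise unchanged structure. Exchanging chlorine for fluorine in this group therefore produces no readable difference, and neither compound 1 nor compound 4 shows a strong effect at the one concentration tested. No available measurement bears on why the two groups read alike.

From the compounds shown here alone, it remains open whether a group of a different kind at this carbonyl carbon, such as a carboxylic acid, a nitrile or a morpholine ring, would separate from 3,4-dichlorophenyl beyond the scatter. Also unresolved is whether compound 1 and compound 4 stay alike at other concentrations.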